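This account rests on a few compounds, and the source may have more. Where it says the series, first, only, none or still open, it means among the compounds named here.

In an ADME assay on LLC-MK2 cells (Macaca mulatta) for cytotoxicity, read by MTT assay, with a stated time of 48 h (a lower number here means that less compound is tolerated, a higher number that more compound is tolerated), compound 1 (`COc1ccc(/C=C/C(=O)/C(C)=C/c2ccccc2)cc1`) gives 93000 nM, compound 2 (`COc1ccc(/C=C(\C)C(=O)/C=C/c2ccc(N(C)C)cc2)cc1`) gives 411000 nM and compound 3 (`COc1ccc(/C=C/C(=O)/C(C)=C/c2ccc([N+](=O)[O-])cc2)cc1`) gives 172000 nM. Compound 3 therefore stands within the usual scatter of compound 1, while compound 2 lies beyond the scatter on the higher side of compound 3. Compound 4 (`C/C(=C\c1ccc([N+](=O)[O-])cc1)C(=O)/C=C/c1ccc(N(C)C)cc1`) is compound 3 with dimethylamino in place of methoxy on an aromatic carbon, para to a large group: dimethylamino in place of methoxy on an aromatic carbon. Within the data shown here, no measured pair shows this exact swap. Among the measured compounds shown here, the only measured step is a different change, nitro in place of hydrogen on an aromatic carbon, and it gives a 1.8-fold higher number from compound 1 to compound 3 (0.27 log units; within the scatter), so it offers little guidance. The nearest hint is compound 2, which carries dimethylamino and gives 411000 nM, although it also differs from compound 3 elsewhere. A small upward shift in this assay, no larger than the scatter, is thus expected, and the estimated step is a 1.5-fold higher number from compound 3 to compound 4 (0.16 log units; within the scatter). The estimate for compound 4 is 250000 nM, with an expected range from 100000 nM to 600000 nM.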

Compound 4, half-maximal cytotoxic concentration: 25900 nM
Compound 4: the middle estimate sits 9.7-fold (0.98 log units) above what was measured, and the stated range ends above it.
By their numbers in this assay, from the lowest: compound 4; then compounds 1 and 3 (each within the scatter of the next); then compound 2.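

In this assay, dimethylamino in place of methoxy on an aromatic carbon, para to a large group, proves a real change when nitro is also present, giving a 6.6-fold lower number from compound 3 to compound 4 (0.82 log units; beyond the scatter) and not the small shift that compound 2 hinted at. With dimethylamino kept, nitro in place of methoxy gives a 16-fold lower number from compound 2 to compound 4 (1.20 log units; beyond the scatter), whereas nitro in place of hydrogen earlier stayed within the scatter, so in these compounds the effect of one group depends on what else the molecule carries. Nothing measured here explains these drops.

Still open, from the compounds shown here alone, is whether dimethylamino lowers the number in the same way in a compound without nitro. Going by these compounds, how a smaller group at this place, such as a hydroxyl or a chlorine atom, would compare also remains unknown.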